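Swapping a sulfoxide-bearing ring for an aminopyridine

A few compounds are considered here, and "the series" means these few. Any claim that something is new, unique, unknown or untested is made for them only; others in the source may bear on it.

Measured so far:
- compound 1 `CS(=O)(=O)c1ccc(-c2cnc3ccc(-c4cncc(C(F)(F)F)c4)nn23)cc1`: < 5000 nM
- compound 2 `C[S+]([O-])c1cccc(-c2ccc3ncc(-c4ccc(S(C)(=O)=O)cc4)n3n2)c1`: 188000 nM

Of the compounds shown here, two share a core and have been tested in a physicochemical assay for solubility, at pH 2; on this read-out higher numbers stand for higher solubility and lower numbers for lower solubility. For compound 1 the result is only a limit of the assay, < 5000 nM, so no number is known for it; this is the limit of < 5000 nM in this assay, at which 1 of the 2 values shown sits. Going by the values given here, compound 2 is therefore the only compound with an actual number, giving 188000 nM in this assay.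

Compound 3 `CS(=O)(=O)c1ccc(-c2cnc3ccc(-c4cncc(N)c4)nn23)cc1` is the next compound to be measured. It differs from compound 2 in one place: a group of 7 heavy atoms (5 carbon, 2 nitrogen; one six-membered aromatic ring with 1 hetero atom) in place of a group of 9 heavy atoms (7 carbon, 1 oxygen, 1 sulfur; one six-membered aromatic ring of carbon only), on an aromatic carbon. Among the compounds with values here, no step between measured compounds bears on this change, so there is nothing to calibrate against. The expected step from compound 2 to compound 3 is a 1.6-fold lower number from compound 2 to compound 3 (0.19 log units; within the scatter), a modest shift not confidently beyond the scatter. Compound 3 is estimated at 120000 nM in this assay, most likely between 20000 nM and 600000 nM.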

Compound 3, solubility: 174000 nM
Beside the measured number, compound 3's estimate is 1.5-fold (0.16 log units) below it; low and high end bracket the measured number.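

Amino in place of trifluoromethyl on the pyridine ring gives an at least 34-fold higher number from compound 1 to compound 3 (1.54 log units; beyond the scatter) in this assay, the first step in this series that lies beyond the scatter. From the compounds shown here alone, compound 1 gives only a limit of the assay and not a number, so the true size of this step stays unknown: the limit of < 5000 nM in this assay, at which 1 of the 3 values shown sits. By contrast, a much larger change at the aromatic carbon of the shared core, with 5-aminopyridin-3-yl entering for the sulfoxide-bearing ring, gives a 1.1-fold lower number from compound 2 to compound 3 (0.03 log units; within the scatter), so on this read-out the two groups cannot be told apart.

Going by these compounds, how a methyl, a hydroxyl or a dimethylamino group would compare with amino on the same ring remains open. Also open, on these data alone, is whether a carboxylic acid there would fall nearer compound 1 or compound 3 in this assay.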